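Carbamate substitution on the piperidine side chain

A few compounds are considered here, and "the series" means these few. Any claim that something is new, unique, unknown or untested is made for them only; others in the source may bear on it.

Measured so far:
compound 1, `CC(C)(C)OC(=O)NCC1CCCN(C(=O)CN2CN(c3ccccc3)C3(CCN(C(=O)c4ccc(C5CCCCC5)cc4)CC3)C2=O)C1`, 3800 nM
compound 2, `CC1CCCN(C(=O)CN2CN(c3ccccc3)C3(CCN(C(=O)c4ccc(C(C)(C)C)cc4)CC3)C2=O)C1`, 12000 nM

Both compounds share one core and were read in an assay on HEK293 cells for displacement of a labelled ligand from NPC1-like intracellular cholesterol transporter 1 (Homo sapiens); on this read-out higher numbers stand for weaker inhibition and lower numbers for stronger inhibition. Compound 2 stands at the highest of the two numbers; compound 1 sits at a lower number, and the gap from compound 2 to compound 1 lies beyond the usual scatter. Compound 1 and compound 2 differ in two places at once, so their two values alone do not show which change carries that gap.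

Compound 3, `CC(C)(C)OC(=O)NCC1CCCN(C(=O)CN2CN(c3ccccc3)C3(CCN(C(=O)c4ccc(C(C)(C)C)cc4)CC3)C2=O)C1`, is not yet measured. It differs from compound 2 in one place: (tert-butoxycarbonyl)amino in place of hydrogen on a saturated chain carbon bound to a saturated ring carbon. The aromatic substituent of compound 2 is kept, so compound 3 combines the side chain of compound 1 with the amide of compound 2. For the measured compounds named here, no single-change step between measured compounds exists, so the size of this change cannot be read off directly. Because compound 1 gives 3800 nM where compound 2 gives 12000 nM, and compound 3 carries the side chain of compound 1, a move toward a lower number is expected. The expected step is a 2.2-fold lower number from compound 2 to compound 3 (0.34 log units; beyond the scatter), modest in size. The estimate for compound 3 in this assay is 5500 nM, with a range from 2000 nM to 15000 nM.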

Compound 3, half-maximal inhibitory concentration: 9500 nM
Compound 3: the middle estimate sits 1.7-fold (0.24 log units) below what was measured; measured number inside the range.
By their numbers in this assay, from the lowest: compound 1; then compounds 3 and 2 (each within the scatter of the next).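

In this assay, placing (tert-butoxycarbonyl)amino in place of hydrogen on a saturated chain carbon bound to a saturated ring carbon gives a 1.3-fold lower number from compound 2 to compound 3 (0.10 log units; within the scatter) with tert-butyl kept on the aromatic carbon, so the carbamate side chain shows no resolved effect in this setting. Tert-butyl in place of cyclohexyl on an aromatic carbon, with the side chain kept, gives a 2.5-fold higher number from compound 1 to compound 3 (0.40 log units; beyond the scatter) and thus, of the two single changes that link these compounds, only the one at the aromatic substituent lies beyond the scatter. Nothing available speaks to the reason for either step.

The compounds shown leave open whether the side-chain change would read the same with cyclohexyl on the aromatic carbon, and whether a free amine or a carboxylic acid at the end of that chain would separate from methyl where the (tert-butoxycarbonyl)amino group does not. Also open, as far as these compounds go, is whether the step at the aromatic carbon continues with other groups there, such as phenyl or a longer alkyl chain.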